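Urea series: methyl-for-hydrogen steps on the alkyl chain

The source may report more compounds than this note shows. Statements on the series, on what has been measured and on what is new or still open speak of the compounds shown alone.

Measured so far:
Compound 1 `CCc1ccc(NC(=O)N[C@@H](C)c2ccccc2)cc1` gives 99% in an ADME assay on the whole organism with Oryza sativa as the target, tested at 0.1 uM; on this read-out higher numbers stand for a weaker effect at the one concentration tested and lower numbers for a stronger effect.
Compound 2 `CC(C)c1ccccc1NC(=O)N[C@H](C)c1ccccc1` gives 103% in this assay.
Compound 3 `CCCc1ccc(NC(=O)N[C@@H](C)c2ccccc2)cc1` gives 97% in this assay.

All three measured compounds sit at essentially full read-out in this assay, meaning very little effect at the single concentration tested. Going by the values given here, the one counted step between measured compounds is the change (methyl in place of hydrogen on a saturated chain carbon, two bonds along the chain from an aromatic carbon), which produced a number 2 percentage points lower from compound 1 to compound 3 (within the scatter). Compound 2 differs from compound 1 in more than one place; the difference between the two cores is not broken down here. Compound 2 lies within the scatter of compound 1 and of compound 3, so no ordering among the three can be drawn.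

Compound 4 `C[C@@H](NC(=O)Nc1ccccc1C(C)(C)C)c1ccccc1` has not yet been measured. It differs from compound 2 by methyl in place of hydrogen on a saturated chain carbon bound to an aromatic carbon and two saturated chain carbons. This is the same kind of change as from compound 1 to compound 3, but not the same: there the methyl entered on a saturated chain carbon two bonds along the chain from an aromatic carbon, whereas here it enters on a saturated chain carbon bound to an aromatic carbon and two saturated chain carbons.

For compound 4 a step of a number 2 percentage points lower from compound 2 to compound 4 (within the scatter) is expected in this assay, beside the measured a number 2 percentage points lower from compound 1 to compound 3 (within the scatter), because a number 2 percentage points lower from compound 1 to compound 3 (within the scatter) shows that adding a methyl on the chain left the read-out within the scatter. Compound 4 is therefore estimated at 101%, with a range of 91% to 110%.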

Compound 4, a percentage reported as activity, at one concentration (the size of the read-out at that concentration, not a potency): 100%
The estimate for compound 4 lay 1 percentage points above the measured number; measured number inside the range.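

In this assay the isopropyl to tert-butyl change gives a number 3 percentage points lower from compound 2 to compound 4 (within the scatter), so this methyl-for-hydrogen change leaves the read-out within the scatter on the core of compound 2, as it does on the core of compound 1. Going by these compounds alone, the two steps agree, and within this pair the change carries from one core to the other as a step that cannot be told from no step at all: the same change on two cores in this assay, a number 2 percentage points lower (within the scatter) from compound 1 to compound 3 and a number 3 percentage points lower (within the scatter) from compound 2 to compound 4, 1 percentage points apart, within the scatter of two such steps.

This does not show that a measurable effect of the methyl transfers between the cores, since neither step is distinguishable from the scatter, all four compounds lie close together near full read-out, and the methyl enters at a different place in each case, on a saturated chain carbon two bonds along the chain from an aromatic carbon in one and on a saturated chain carbon bound to an aromatic carbon and two saturated chain carbons in the other.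

Still open, going by these compounds, is whether any group outside these small alkyl groups, such as a longer chain like n-hexyl, an amine or a carboxylic acid, would move the read-out beyond the scatter on either core. Also open, on these data alone, is whether the two steps would still agree at a concentration other than the single one tested here.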